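The compounds below may be only part of what the source reports. "The series", "measured", "known", "first", "only" and "open" are said of these compounds alone.

Of the compounds shown here, three sharing one core have been measured in an assay on HEK293 cells for inhibition of Voltage-dependent T-type calcium channel subunit alpha-1G (Homo sapiens), read by fluorescence, tested at 10 uM; on this read-out higher numbers stand for more inhibition at the one concentration tested (going by the name of the read-out) and lower numbers for less inhibition. Compound 1 `CCCc1nc(-c2ccccc2)c(CNCCN2CCN(c3ccc(Cl)cc3)CC2)o1` gives 55.8% in this assay. Compound 2 `CCCc1nc(-c2ccccc2)c(CNCCN2CCN(c3ccccc3C)CC2)o1` gives 51.3%. These two differ in one place: 4-chlorophenyl in place of 2-methylphenyl on an amine nitrogen in a ring This exchange made a step of a number 4.5 percentage points higher from compound 2 to compound 1 (within the scatter). Compound 3 `CCCc1nc(-c2ccccc2)c(CNCCCN2CCN(c3ccccc3C)CC2)o1` gives 54.5%; how its core differs from the core of compound 2 is not broken down here. All three numbers lie within the usual scatter of one another, so none of them can be told apart on this read-out.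

Compound 4 `CCCc1nc(-c2ccccc2)c(CNCCCN2CCN(c3ccc(Cl)cc3)CC2)o1` has not yet been measured. It differs from compound 3 in one place: 4-chlorophenyl in place of 2-methylphenyl on an amine nitrogen in a ring The place is the same, word for word, as in the change from compound 2 to compound 1, so this is the same change made a second time. Because that earlier change gave a number 4.5 percentage points higher from compound 2 to compound 1 (within the scatter), a step of about the same size is expected here, namely a number 4.5 percentage points higher from compound 3 to compound 4 (within the scatter). Compound 4 is therefore estimated at 59%, with a range from 46% to 72%; a single earlier example of this change cannot narrow the expectation beyond the usual scatter.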

Compound 4, a percentage reported as inhibition, at one concentration (the size of the read-out at that concentration, not a potency): 63.3%
Estimate against measurement, compound 4: 4.3 percentage points below; the measured number falls inside the stated range.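

In this assay, putting 4-chlorophenyl in place of 2-methylphenyl on an amine nitrogen in a ring gave a number 8.8 percentage points higher from compound 3 to compound 4 (within the scatter). Set beside its first appearance, the same exchange behaves alike on the two cores, with no difference that can be told apart: the same change on two cores in this assay, a number 4.5 percentage points higher (within the scatter) from compound 2 to compound 1 and a number 8.8 percentage points higher (within the scatter) from compound 3 to compound 4, 4.3 percentage points apart, within the scatter of two such steps. This shows that the earlier step was a fair guide for the second core, but each step lies within the scatter on its own, so it does not show that the exchange truly alters inhibition, and two cores cannot show how it behaves across the wider series.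

The compounds shown leave open how a plain phenyl, a 4-fluorophenyl or a 4-methoxyphenyl would read in the same place. They also leave open whether a longer chain in the core of compound 4 would give a step of similar size, and whether a potency measured across several concentrations would tell these compounds apart.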